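The compounds below may be only part of what the source reports. "The series", "measured", "known", "first", "only" and "open" are said of these compounds alone.

Measured compounds:
compound 1 `COc1ccc(/C=C/c2cc(OC)cc(OC)c2/C=C/C(=O)c2cc3ccccc3oc2=O)cc1`: 41700 nM
compound 2 `COc1ccc(/C=C/c2cc(OC)cc(OC)c2/C=C/C(=O)c2cc3ccc(Br)cc3oc2=O)cc1`: 3010 nM

In an assay on isolated protein for inhibition of Amine oxidase [flavin-containing] A (Homo sapiens), read by fluorescence, with a stated time of 15 min (on this read-out lower numbers stand for stronger inhibition and higher numbers for weaker inhibition), compound 2 gives the lowest of the two numbers; its nearest neighbour is compound 1, which sits well above it. Going by the values given here, the one measured step that bears on the present question is a 14-fold lower number from compound 1 to compound 2 (1.14 log units; beyond the scatter), a change confined to the bicyclic group on the carbonyl carbon.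

Compound 3 `COc1ccc(/C=C/c2cc(OC)cc(OC)c2/C=C/C(=O)c2cc3cc(Br)ccc3oc2=O)cc1` is built from the same atoms as compound 2 but joined differently: a group of 12 heavy atoms (9 carbon, 2 oxygen, 1 bromine; one six-membered aromatic ring of carbon only, one six-membered aromatic ring with 1 hetero atom) in place of a group of 12 heavy atoms (9 carbon, 2 oxygen, 1 bromine; one six-membered aromatic ring of carbon only, one six-membered aromatic ring with 1 hetero atom), on a carbonyl carbon. Among the compounds with values here, no measured pair shows what rearranging the bromine within that group does, so the only anchor is that compound 2 carries a bromine on this group at all and compound 1 does not. Compound 3 is therefore expected to stay nearer compound 2 than compound 1, with a step of a 1.7-fold higher number from compound 2 to compound 3 (0.22 log units; within the scatter) that is estimated as small. The estimate for compound 3 is 5000 nM, with a range from 1500 nM to 20000 nM.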

Compound 3, half-maximal inhibitory concentration: 12100 nM
Beside the measured number, compound 3's estimate is 2.4-fold (0.38 log units) below it; the range from low to high includes it.
By their numbers in this assay, from the lowest: compound 2; then compound 3; then compound 1.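

In this assay, going by these compounds alone, the placement of the bromine on the bicyclic group matters: with the same atoms joined differently, the result is a 4.0-fold higher number from compound 2 to compound 3 (0.60 log units; beyond the scatter), a step beyond the scatter that the earlier compounds could not reveal. The bromine keeps a benefit in its new place, with a 3.4-fold lower number from compound 1 to compound 3 (0.54 log units; beyond the scatter), but this gain is smaller than the earlier 14-fold lower number from compound 1 to compound 2 (1.14 log units; beyond the scatter), so the effect of adding bromine to this group depends on where it is attached. No available evidence accounts for the difference between the two placements.

The compounds shown leave open whether the gain belongs to bromine in particular or would also appear with a chloro group, a methoxy group or an amine on the same group. They also leave open how bromine would fare on the other carbons of that group.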